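This account rests on a few compounds, and the source may have more. Where it says the series, first, only, none or still open, it means among the compounds named here.

Within the data shown here, in a functional assay on PC-3 cells (Homo sapiens) for cytotoxicity, read by WST assay, with a stated time of 48 h (on this read-out higher numbers stand for weaker inhibition and lower numbers for stronger inhibition), compound 1 (`COc1ccc2[nH]cc(/C=C(\C#N)C(=O)c3c[nH]c4ccccc34)c2c1`) gives 30500 nM, the higher of the two exact numbers available so far, while compound 3 (`COc1ccc(-c2[nH]c3ccccc3c2/C=C(\C#N)C(=O)c2c[nH]c3ccccc23)cc1`) gives 8100 nM. Compound 2 (`COc1ccc2[nH]cc(/C=C(\C#N)C(=O)c3c[nH]c4ccc(OC)cc34)c2c1`) is reported only as a limit of the assay, > 50000 nM. Compound 4 (`COc1ccc2c(C(=O)/C(C#N)=C/c3c[nH]c4ccc(OC)cc34)c[nH]c2c1`) has not yet been measured. It differs from compound 1 by methoxy in place of hydrogen on an aromatic carbon, a methoxy in place of hydrogen on an aromatic carbon. Among the measured compounds shown here, the one measured step involving the same kind of replacement is an at least 1.6-fold higher number from compound 1 to compound 2 (0.21 log units; that floor lies within the scatter). That single step offers only weak guidance, but it points towards a higher number, not a lower one, so no step beyond the scatter is firmly expected in this assay. The expected change is a small rise, a 1.3-fold higher number from compound 1 to compound 4 (0.12 log units; within the scatter). A result for compound 4 reported only as a limit would be no surprise, given (the limit of > 50000 nM in this assay, at which 1 of the 3 values shown sits). For compound 4 the estimated value is 40000 nM, with an expected range of 14000 nM to 80000 nM.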

Compound 4, half-maximal inhibitory concentration: 37100 nM
The estimate for compound 4 lay 1.1-fold (0.03 log units) above the measured number; the range from low to high includes it.
By their numbers in this assay, from the lowest: compound 3; then compounds 1 and 4 (each within the scatter of the next). At a limit, above all of these: compound 2.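

Among these compounds, the new step, a 1.2-fold higher number from compound 1 to compound 4 (0.09 log units; within the scatter), gives the first exact reading of this replacement in this assay, so the numbers of the two compounds cannot be told apart. Methoxy on this aromatic carbon, meta to a fused ring and para to a fused ring, therefore leaves the read-out of compound 1 within the usual scatter. The earlier comparison could not show this, since compound 2 is reported only as a limit, > 50000 nM, and one value shown still stands as such a limit: the limit of > 50000 nM in this assay, at which 1 of the 4 values shown sits.

The compounds shown leave open whether an amine, a carboxylic acid or a longer chain such as ethoxy on this carbon would give a step beyond the scatter. They also leave open whether the same methoxy would behave alike on compound 3, which gives 8100 nM.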